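Adding a methyl to the ring: an estimate for compound 4

The compounds below may be only part of what the source reports. "The series", "measured", "known", "first", "only" and "open" are said of these compounds alone.

Compound 1 `Cc1cc(Cl)c(S(C)(=O)=O)cc1C(=O)N=C(N)N` gives 25 nM in a functional assay for inhibition of sodium/hydrogen exchanger (Oryctolagus cuniculus); on this read-out lower numbers stand for stronger inhibition and higher numbers for weaker inhibition. Compound 2 `Cc1c(C(=O)N=C(N)N)cc(S(C)(=O)=O)c(Cl)c1C` carries methyl in place of hydrogen on an aromatic carbon and gives 58 nM in this assay, the step being a 2.3-fold higher number from compound 1 to compound 2 (0.37 log units; beyond the scatter). Compound 3 `Cc1cc(C)c(S(C)(=O)=O)cc1C(=O)N=C(N)N` differs from compound 1 by methyl in place of chloro on an aromatic carbon; in this assay compound 3 gives 11 nM, a step of a 2.3-fold lower number from compound 1 to compound 3 (0.36 log units; beyond the scatter); among the three compounds it has the lowest number. Compound 4 `Cc1c(C(=O)N=C(N)N)cc(S(C)(=O)=O)c(C)c1C` is not yet measured; relative to compound 3 it carries methyl in place of hydrogen on an aromatic carbon. Going by the values given here, this is the same kind of change as the one from compound 1 to compound 2, not the same: there the methyl entered ortho to a chloro group and ortho to a methyl group, whereas in compound 4 it enters ortho to two methyl groups. Compound 4 is expected to give 25 nM in this assay, with a range from 12 nM to 55 nM. That expectation rests on the step of a 2.3-fold higher number from compound 1 to compound 2 (0.37 log units; beyond the scatter), which suggests an expected step of a 2.3-fold higher number from compound 3 to compound 4 (0.36 log units; beyond the scatter).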

Compound 4, half-maximal inhibitory concentration: 55 nM
The estimate for compound 4 lay 2.2-fold (0.34 log units) below the measured number; measured number inside the range.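

In this assay the added methyl gives a 5.0-fold higher number from compound 3 to compound 4 (0.70 log units; beyond the scatter), the same direction as on the core of compound 1, and the two steps cannot be told apart: the same change on two cores in this assay, a 2.3-fold higher number (0.37 log units; beyond the scatter) from compound 1 to compound 2 and a 5.0-fold higher number (0.70 log units; beyond the scatter) from compound 3 to compound 4, 2.2-fold (0.33 log units) apart, within the scatter of two such steps. Methyl in place of chloro gives a 1.1-fold lower number from compound 2 to compound 4 (0.02 log units; within the scatter), and this step too cannot be told apart from its earlier counterpart: the same change on two cores in this assay, a 2.3-fold lower number (0.36 log units; beyond the scatter) from compound 1 to compound 3 and a 1.1-fold lower number (0.02 log units; within the scatter) from compound 2 to compound 4, 2.2-fold (0.33 log units) apart, within the scatter of two such steps. The change thus carried over between these two cores, but a single pair of steps for each change shows neither a fixed size nor that it would hold on any other core.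

What the compounds shown leave open is how a group other than methyl, such as an ethyl, a methoxy or an amine, would fare on this aromatic carbon.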